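Cytotoxicity notes: anilino replaces 4-hydroxyphenyl on compound 1

The source may report more compounds than this note shows. Statements on the series, on what has been measured and on what is new or still open speak of the compounds shown alone.

The series shares one core, carried into compound 1 `O=C1Nc2ccc(S(=O)(=O)N3CCOCC3)cc2/C1=N/c1ccc(O)cc1`, compound 2 `CC(=O)c1cccc(/N=C2\C(=O)Nc3ccc(S(=O)(=O)N4CCOCC4)cc32)c1` and compound 3 `Cc1ccc(/N=C2\C(=O)Nc3ccc(S(=O)(=O)N4CCOCC4)cc32)cc1`. In an ADME assay on WI-38 cells (Homo sapiens) for cytotoxicity, read by sulforhodamine B assay, with a stated time of 24 h (a higher number here means a weaker inhibitor, a lower number a stronger inhibitor), compound 1 gives 259000 nM, compound 2 gives 177000 nM and compound 3 gives 309000 nM. Compound 1 stands second highest of the three numbers; its nearest neighbour is compound 3 and its furthest is compound 2, both within the scatter. The steps among the measured compounds are small: a 1.5-fold lower number from compound 1 to compound 2 (0.17 log units; within the scatter), a 1.2-fold higher number from compound 1 to compound 3 (0.08 log units; within the scatter) and a 1.7-fold higher number from compound 2 to compound 3 (0.24 log units; within the scatter), none beyond the scatter.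

The next compound, compound 4 `O=C1Nc2ccc(S(=O)(=O)N3CCOCC3)cc2/C1=N/Nc1ccccc1`, differs from compound 1 in one place: anilino in place of 4-hydroxyphenyl on a double-bonded nitrogen. The steps from compound 1 to compound 2 and from compound 2 to compound 3 also exchange the group on the double-bonded nitrogen, and neither moved this assay beyond the scatter. Among the compounds with values here, no measured step covers an anilino group, so the expectation rests on those exchanges alone, and no step beyond the scatter is expected from compound 1 to compound 4, a 1.0-fold lower number from compound 1 to compound 4 (0.02 log units; within the scatter). Compound 4 is therefore estimated at 250000 nM in this assay, within a range of 120000 nM to 520000 nM.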

Compound 4, half-maximal inhibitory concentration: 262000 nM
Beside the measured number, compound 4's estimate is 1.0-fold (0.02 log units) below it; low and high end bracket the measured number.
By their numbers in this assay, from the lowest: compounds 2, 1, 4 and 3 (each within the scatter of the next).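

In this assay the anilino group is the only group shown that holds its aromatic ring on the double-bonded nitrogen through a further nitrogen, and a 1.0-fold higher number from compound 1 to compound 4 (0.01 log units; within the scatter) shows that this extra link, with 4-hydroxyphenyl and anilino matching in their heavy-atom, donor and acceptor counts and differing in one oxygen against one nitrogen, leaves the number within the scatter. Within the data shown here, the comparison with the other two groups reads the same way, since a 1.2-fold lower number from compound 3 to compound 4 (0.07 log units; within the scatter) and a 1.5-fold higher number from compound 2 to compound 4 (0.17 log units; within the scatter) also stay within it, so across compounds 1 to 4 all four groups at this position sit within the scatter of one another, with no compound among them going against this. No measurement at hand speaks to the reason for this flat picture.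

The compounds shown leave open whether an amine or a carboxylic acid on the aromatic ring of the anilino group, or a longer chain in its place on the double-bonded nitrogen, would also stay within the scatter. Every exchange here keeps the shared core fixed, so the effect of changes elsewhere on that core remains unread in this assay for now.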